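One Added Methyl on a Methoxy Group

This account rests on a few compounds, and the source may have more. Where it says the series, first, only, none or still open, it means among the compounds named here.

Of the two compounds tested, only compound 2 (`COc1cc2occ(-c3csc4ccccc34)c(=O)c2c(OC)c1OC`) returns an actual number in a functional assay on KB cells (Homo sapiens) for antiproliferative activity, read by sulforhodamine B assay, with a stated time of 72 h (on this read-out lower numbers stand for stronger inhibition and higher numbers for weaker inhibition), where compound 2 gives 820 nM as its half-maximal inhibitory concentration. Compound 1 (`COc1c(O)cc2occ(-c3csc4ccccc34)c(=O)c2c1O`) is recorded as > 10000 nM in this assay and that figure is a limit of the assay, not a number. Compound 2 therefore stands alone as the only measured reference point.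

Compound 3 (`CCOc1c(OC)cc2occ(-c3csc4ccccc34)c(=O)c2c1OC`) departs from compound 2 by one small change (methyl in place of hydrogen on a saturated chain carbon bound to an oxygen on an aromatic ring): methyl in place of hydrogen on a saturated chain carbon bound to an oxygen on an aromatic ring, so that a methoxy becomes an ethoxy. Among the compounds with values here, no measured pair shows what this change does, so the expectation rests on compound 2 at 820 nM and on the small size of the change. The expected step, a 1.3-fold higher number from compound 2 to compound 3 (0.13 log units; within the scatter) in this estimate, is small, leans toward weaker inhibition and may not exceed the usual scatter. Compound 3 is estimated at 1100 nM in this assay, with an expected range from 350 nM to 4000 nM in that assay.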

Compound 3, half-maximal inhibitory concentration: 4000 nM
Compound 3: the middle estimate sits 3.6-fold (0.56 log units) below what was measured, within the range that was stated.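

In this assay, within the data shown here, this is the first measured pair to show that the methoxy group named here does not tolerate every enlargement without cost: methyl in place of hydrogen on a saturated chain carbon bound to an oxygen on an aromatic ring, turning methoxy into ethoxy, gives a 4.9-fold higher number from compound 2 to compound 3 (0.69 log units; beyond the scatter). A single added methyl therefore moves the number beyond the scatter, although compound 3 still gives a measured value of 4000 nM rather than a limit. Compound 1 remains a limit of the assay and not a number, and it differs from the other compounds in more than one place, so no step to it can be read: the limit of > 10000 nM in this assay, at which 1 of the 3 values shown sits.

With one step at one place, the compounds shown leave open whether a longer chain such as propoxy would push the number further in the same direction or whether the change from methoxy to ethoxy is a one-off. They also leave open whether the same change on either of the other methoxy groups would have a similar effect, and how an amine or a carboxylic acid at the end of the chain would read.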